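This account rests on a few compounds, and the source may have more. Where it says the series, first, only, none or still open, it means among the compounds named here.

Measured compounds:
- Compound 1, `COc1cc(C(c2ccc(O)c(OC)c2)[C@@H](C)[C@H](C)CF)ccc1O`, in a functional assay on HL-60 cells (Homo sapiens) for cytotoxicity, read by WST assay, with a stated time of 48 h; a lower number here means a stronger inhibitor, a higher number a weaker inhibitor: 32000 nM
- Compound 2, `COc1cc(C(c2ccc(O)c(OC)c2)[C@H](C)C(C)C)ccc1O`, in this assay: 17000 nM
- Compound 3, `COc1cc(C(c2ccc(O)c(OC)c2)[C@@H](CF)C(C)C)ccc1O`, in this assay: 39000 nM

Among these three numbers compound 1 holds the second highest place. Its nearest neighbour is compound 3, with a 1.2-fold higher number from compound 1 to compound 3 (0.09 log units; within the scatter), and its furthest is compound 2, with a 1.9-fold lower number from compound 1 to compound 2 (0.27 log units; within the scatter); neither of these steps leaves the scatter, so the three compounds cannot be told apart with confidence. Going by the values given here, only the step of a 2.3-fold higher number from compound 2 to compound 3 (0.36 log units; beyond the scatter) reaches a modest size.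

The new compound 4, `COC[C@@H](C)[C@@H](C)C(c1ccc(O)c(OC)c1)c1ccc(O)c(OC)c1`, differs from compound 1 in the following way: 2-(methoxymethyl)-1-methylpropyl in place of 2-(fluoromethyl)-1-methylpropyl on a saturated chain carbon bound to two aromatic carbons

Among the compounds with values here, the steps that bear on this change are those that also altered the same side chain on the shared core. The step of a 1.9-fold lower number from compound 1 to compound 2 (0.27 log units; within the scatter) swaps the fluoromethyl for a methyl and stays within the scatter; the step of a 1.2-fold higher number from compound 1 to compound 3 (0.09 log units; within the scatter) moves the fluoromethyl to another chain carbon and also stays within the scatter. Replacing the fluorine by a methoxy group is a change of similar scale on the same chain, so in this assay no step beyond the scatter is expected in either direction. Compound 4 is therefore estimated at 30000 nM, with a range from 14000 nM to 65000 nM, which corresponds to an expected step of a 1.1-fold lower number from compound 1 to compound 4 (0.03 log units; within the scatter).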

Compound 4, half-maximal inhibitory concentration: 85000 nM
Compound 4: the middle estimate sits 2.8-fold (0.45 log units) below what was measured, outside the stated range (above it).
By their numbers in this assay, from the lowest: compounds 2, 1 and 3 (each within the scatter of the next, the first and the last beyond it); then compound 4.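

In this assay, the earlier changes to this side chain mostly stayed within the scatter, but 2-(methoxymethyl)-1-methylpropyl in place of 2-(fluoromethyl)-1-methylpropyl gives a clear rise (a 2.7-fold higher number from compound 1 to compound 4 (0.42 log units; beyond the scatter)), so this position does respond to a change at the end of the chain. The rise also holds against the other two compounds (a 2.2-fold higher number from compound 3 to compound 4 (0.34 log units; beyond the scatter); a 5.0-fold higher number from compound 2 to compound 4 (0.70 log units; beyond the scatter)), which places compound 4 as the weakest inhibitor of the four, and the step from the methyl-ended chain of compound 2 is the largest in the set. Nothing available explains why the methoxy-ended chain gives the highest number.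

The compounds shown leave open whether the rise follows the oxygen itself or the extra carbon attached to it, a question that a hydroxymethyl or an ethyl group at the same place could help to separate. They also leave open how an aminomethyl or a carboxylic acid group at the end of this chain would behave in this assay, and whether any group there could bring the number well below that of compound 2.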